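Acrylamide versus crotonamide on two cores

The source may hold more compounds than are shown below. What is called first, only, known or untested is meant among the compounds shown, and "the series" means these compounds.

Measured compounds:
compound 1 `C/C=C/C(=O)Nc1cccc(Cn2nc(-c3ccc(Oc4ccccc4)cc3)cc2CO)c1`, 3400 nM
compound 2 `C=CC(=O)Nc1cccc(Cn2nc(-c3ccc(Oc4ccccc4)cc3)cc2CO)c1`, 1300 nM
compound 3 `C/C=C/C(=O)N1CCCC(n2nc(-c3ccc(Oc4ccccc4)cc3)cc2CO)C1`, 27200 nM

All three numbers come from a functional assay on Rec1 cells (Homo sapiens) for inhibition, read by luminescence and CellTiter-Glo, with a stated time of 72 h; on this read-out higher numbers stand for weaker inhibition and lower numbers for stronger inhibition. Compound 1 and compound 2 share one core and differ by vinyl in place of prop-1-en-1-yl on a carbonyl carbon; the step is a 2.6-fold lower number from compound 1 to compound 2 (0.42 log units; beyond the scatter). Compound 3 has a different core, and the difference between the two cores is not broken down here; its value stands well above those of compound 1 and compound 2.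

Compound 4 `C=CC(=O)N1CCCC(n2nc(-c3ccc(Oc4ccccc4)cc3)cc2CO)C1` is not yet measured. It differs from compound 3 by vinyl in place of prop-1-en-1-yl on a carbonyl carbon. This is the same kind of change as from compound 1 to compound 2, but the place is not identical: in compound 1 the carbonyl carbon is bound to an amide-type nitrogen, in compound 3 to an amide-type nitrogen in a ring.

Among the measured compounds shown here, for compound 4 a step of a 2.6-fold lower number from compound 3 to compound 4 (0.41 log units; beyond the scatter) is expected, because the one measured instance of this change gave a 2.6-fold lower number from compound 1 to compound 2 (0.42 log units; beyond the scatter) in this assay; a ring-bound amide is a different setting, so the expectation is held loosely. Compound 4 is therefore estimated at 10500 nM, with a range from 5000 nM to 25000 nM.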

Compound 4, half-maximal inhibitory concentration: 5400 nM
Compound 4: the middle estimate sits 1.9-fold (0.29 log units) above what was measured, and the stated range covers the measured number.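

In this assay, vinyl in place of prop-1-en-1-yl on a carbonyl carbon lowers the number again on the second core, giving a 5.0-fold lower number from compound 3 to compound 4 (0.70 log units; beyond the scatter), so the direction of the change carries over from the core of compound 1 to the core of compound 3. The size of the step also carries over, and the larger figure on the second core is no sign of a stronger effect there: the same change on two cores in this assay, a 2.6-fold lower number (0.42 log units; beyond the scatter) from compound 1 to compound 2 and a 5.0-fold lower number (0.70 log units; beyond the scatter) from compound 3 to compound 4, 1.9-fold (0.28 log units) apart, within the scatter of two such steps. This rests on two pairs in a single cell read-out, so it shows neither that the change would hold on a third core nor why the number moves.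

Open, going by these compounds, is how the read-out responds to other groups on the same carbonyl carbon, such as a longer chain or a prop-1-en-1-yl chain carrying an amine. Also open, on these data alone, is where an ethyl group in place of vinyl would stand on either core, which would test the double bond itself.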